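Cytotoxicity notes: bromo for fluoro on the anilide ring

This account rests on a few compounds, and the source may have more. Where it says the series, first, only, none or still open, it means among the compounds named here.

Measured so far:
compound 1, `CCOc1ccccc1NC(=O)c1c(NO)cc(-c2ccccc2)oc1=O`: > 20000 nM
compound 2, `O=C(Nc1ccc(F)cc1)c1c(NCCO)cc(-c2cccc(Br)c2)oc1=O`: > 20000 nM

Both values come from an ADME assay on Huh-7 cells (Homo sapiens) for cytotoxicity, with a stated time of 3 days; a higher number here means that more compound is tolerated, a lower number that less compound is tolerated. For compound 1 the value > 20000 nM is a limit of the assay, not a number. For compound 2 the value > 20000 nM is likewise a limit. For the measured compounds named here, compound 2 therefore stands nowhere on a scale of numbers in this assay: its result is a limit, and the one further value shown is a limit as well, as summarized by the limit of > 20000 nM in this assay, at which 2 of the 2 values shown sit.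

The next compound is compound 3, `O=C(Nc1ccc(Br)cc1)c1c(NCCO)cc(-c2cccc(Br)c2)oc1=O`. It differs from compound 2 by bromo in place of fluoro on an aromatic carbon.

Going by the values given here, no step between two measured compounds is available for comparison. Given that compound 2 reached the limit > 20000 nM and compound 1 reached the limit > 20000 nM, the expectation for this assay is a step of no size beyond the scatter, in neither direction. The step that the limit leaves unreadable from compound 2 to compound 3 is expected to be none beyond the scatter. Compound 3 is expected to give 25000 nM, with a range of 12000 nM to 60000 nM, most likely reported again as a limit.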

Compound 3, half-maximal cytotoxic concentration: > 20000 nM
Compound 3: only a limit was reported; the forecaster's own chance of this, stated with the estimate: 80%; the middle value does not contradict the limit.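

Compound 2 and compound 3 both return limits in this assay, and no step can be read between them: the limit of > 20000 nM in this assay, at which 3 of the 3 values shown sit.

The compounds shown leave open at what concentration any of them becomes cytotoxic, and whether bromo in place of fluoro on an aromatic carbon changes that concentration at all.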